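The source may report more compounds than this note shows. Statements on the series, on what has been measured and on what is new or still open speak of the compounds shown alone.

Measured so far in a functional assay on HepG2 cells (Homo sapiens) for cytotoxicity, read by MTT assay, with a stated time of 72 h; on this read-out higher numbers stand for weaker inhibition and lower numbers for stronger inhibition: compound 1 `CNC(=O)c1cc(Oc2ccc(NC(=O)c3nn(-c4cccc(F)c4)c(=O)cc3C)cc2F)ccn1` gives 10200 nM; compound 2 `Cc1cc(=O)n(-c2cccc(F)c2)nc1C(=O)Nc1ccc(Oc2ncnc3sccc23)cc1` gives 18500 nM; compound 3 `Cc1cc(=O)n(-c2ccc(Br)cc2F)nc1C(=O)Nc1ccc(Oc2ncnc3sccc23)c(F)c1` gives 13800 nM.

On these three numbers compound 3 holds the second highest value, and its gaps to compound 2 and to compound 1 both lie within the usual scatter, so the three are not told apart. The unmeasured compound 4 `Cc1cc(=O)n(-c2cccc(F)c2)nc1C(=O)Nc1ccc(Oc2ncnc3sccc23)c(F)c1` differs from compound 3 by 3-fluorophenyl in place of 4-bromo-2-fluorophenyl on an aromatic nitrogen. For the measured compounds named here, no step between measured compounds covers this exchange. Compound 2 already carries the 3-fluorophenyl group and sits at a value within the scatter of compound 3, so no shift beyond the scatter is expected, and compound 4 is estimated at 16000 nM (range 7000 nM to 36000 nM). The expected step from compound 3 to compound 4 is thus a 1.2-fold higher number from compound 3 to compound 4 (0.06 log units; within the scatter).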

Compound 4, half-maximal inhibitory concentration: 24500 nM
Compound 4: the middle estimate sits 1.5-fold (0.19 log units) below what was measured; low and high end bracket the measured number.
By their numbers in this assay, from the lowest: compounds 1, 3, 2 and 4 (each within the scatter of the next, the first and the last beyond it).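

In this assay, the exchange on the aromatic nitrogen gives a 1.8-fold higher number from compound 3 to compound 4 (0.25 log units; within the scatter), and fluoro in place of hydrogen on an aromatic carbon gives a 1.3-fold higher number from compound 2 to compound 4 (0.12 log units; within the scatter), so at this position neither losing the bromine with the exchange of the aryl group nor adding that fluoro moves the read-out beyond the scatter. Only the exchange of the group on the oxygen, a 2.4-fold higher number from compound 1 to compound 4 (0.38 log units; beyond the scatter), goes beyond it, and modestly. Nothing at hand explains these steps. Still open, on these data alone, is whether a pyridine ring or a longer alkyl chain on that aromatic nitrogen would shift the number beyond the scatter.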